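Amide nitrogen substituent changes on a shared core

The compounds below may be only part of what the source reports. "The series", "measured", "known", "first", "only" and "open" are said of these compounds alone.

Three compounds of the series carry the same acid-bearing core and differ only in the group on the amide-type nitrogen. Compound 1 `COc1cc(-c2cc(C(=O)O)c3ccccc3n2)ccc1OCC(=O)Nc1cccc(C)c1` gives, in an ADME assay on HaCaT cells (Homo sapiens) for inhibition (on this read-out lower numbers stand for stronger inhibition and higher numbers for weaker inhibition), a value of 225000 nM. Compound 3 `COc1cc(-c2cc(C(=O)O)c3ccccc3n2)ccc1OCC(=O)Nc1ccc(F)cc1` gives in this assay 286000 nM; the step of a 1.3-fold higher number from compound 1 to compound 3 (0.10 log units; within the scatter) shows the two numbers lying within the scatter, so neither stands apart. For compound 2 `COc1cc(-c2cc(C(=O)O)c3ccccc3n2)ccc1OCC(=O)Nc1ccc(C)cc1` this assay reports only a limit, > 300000 nM, as noted in the limit of > 300000 nM in this assay, at which 1 of the 3 values shown sits. The step of an at least 1.3-fold higher number from compound 1 to compound 2 (0.12 log units; that floor lies within the scatter) and the step of an at least 1.0-fold lower number from compound 2 to compound 3 (0.02 log units; that floor lies within the scatter) are likewise within the scatter or carry a floor that lies within it.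

Compound 4 `COc1cc(-c2cc(C(=O)O)c3ccccc3n2)ccc1OCC(=O)Nc1ccccc1Cl` brings the change (2-chlorophenyl in place of 4-fluorophenyl on an amide-type nitrogen). The three measured steps all move the amide nitrogen substituent among substituted phenyl groups, and none of them produced a shift beyond the scatter in this assay. No measured step tests a halogen at the 2-position of the phenyl, so nothing among the shown compounds speaks for a larger move. The expected step is therefore a 1.0-fold higher number from compound 3 to compound 4 (0.01 log units; within the scatter), none beyond the scatter. Compound 4 is expected to give in this assay about 290000 nM, within a range of 150000 nM to 600000 nM, with a real chance that only a limit is reported.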

Compound 4, half-maximal inhibitory concentration: 210000 nM
Beside the measured number, compound 4's estimate is 1.4-fold (0.14 log units) above it; the range from low to high includes it.
By their numbers in this assay, from the lowest: compounds 4, 1 and 3 (each within the scatter of the next). At a limit, above all of these: compound 2.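

With 2-chlorophenyl on the amide-type nitrogen, the series now includes a chlorine-bearing phenyl group at this place, yet a 1.4-fold lower number from compound 3 to compound 4 (0.13 log units; within the scatter) and a 1.1-fold lower number from compound 1 to compound 4 (0.03 log units; within the scatter) show that this change does not separate compound 4 from either neighbour in this assay. The comparison with the 4-methylphenyl group gives only a floor, an at least 1.4-fold lower number from compound 2 to compound 4 (0.15 log units; that floor lies within the scatter), so it adds no evidence of a real difference and leaves the order of that pair unresolved. Compound 2 remains a limit and not a number: the limit of > 300000 nM in this assay, at which 1 of the 4 values shown sits.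

Taken together, the four substituted phenyl groups shown on this nitrogen do not establish any substituent preference in this assay, whether the group carries methyl, fluoro or chloro. Open, on these data alone, is whether a group of another kind on this nitrogen, such as a benzyl, a cyclohexyl or a longer alkyl chain, or a phenyl group bearing an amine or a carboxylic acid, would give a step beyond the scatter from these compounds.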